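The source may hold more compounds than are shown below. What is called first, only, known or untested is meant among the compounds shown, and "the series" means these compounds.

Compound 1 `O[C@H]1CO[C@H](COCc2ccccc2)[C@@H](OCc2ccccc2)[C@@H]1OCc1ccccc1`: > 50000 nM (a limit)
Compound 2 `CC(C)C[C@H]1O[C@H](COCc2ccccc2)[C@@H](OCc2ccccc2)[C@H](OCc2ccccc2)[C@H]1O`: 43900 nM

Going by the values given here, in a functional assay on HeLa cells (Homo sapiens) for antiproliferative activity, read by sulforhodamine B assay (a higher number here means a weaker inhibitor of growth, a lower number a stronger inhibitor of growth), compound 2 gives 43900 nM, the only actual number so far. Compound 1 sits at the limit of > 50000 nM in this assay, at which 1 of the 2 values shown sits.

Among the compounds with values here, the one measured step is an at least 1.1-fold lower number from compound 1 to compound 2 (0.05 log units; that floor lies within the scatter). That step concerns a saturated ring carbon, not the oxygen that changes next, so it bears on the coming change only indirectly.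

Compound 3 `CC(=O)O[C@@H]1[C@@H](OCc2ccccc2)[C@H](OCc2ccccc2)[C@@H](COCc2ccccc2)O[C@@H]1CC(C)C` keeps the core of compound 2 and carries one change: acetyl in place of hydrogen on an oxygen on a saturated carbon. This is hydroxy to acetoxy. Within the data shown here, no measured step covers this change, so no size can be carried over from the data, and no step beyond the scatter is expected in this assay. A reading at the limit also remains possible for compound 3.

The expected step is a 1.5-fold lower number from compound 2 to compound 3 (0.17 log units; within the scatter). For compound 3 the estimated value is 30000 nM, with an expected range of 10000 nM to 60000 nM.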

Compound 3, concentration for 50% growth inhibition: > 50000 nM
Compound 3 gave a limit, no number; the forecaster's own chance of this, stated with the estimate: 25%; middle value at least 1.6-fold (0.22 log units) from the limit.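

In this assay compound 3 gives > 50000 nM, which is a limit and not a number. Acetyl in place of hydrogen on this oxygen gives an at least 1.1-fold higher number from compound 2 to compound 3 (0.05 log units; that floor lies within the scatter), so hydroxy to acetoxy brings no reading below the limit, while the data show no real loss from this change either. The acetoxy compound therefore joins the unacetylated, isobutyl-free compound 1 at the top of the measurable range, and the series now rests on a single actual number: the limit of > 50000 nM in this assay, at which 2 of the 3 values shown sit.

On these data alone, how far compound 3 lies past the limit remains unknown, so the true size of this step cannot be read beyond its floor. Also open, as far as these compounds go, is whether an amine or a carboxylic acid in place of the hydroxy, or a longer chain in place of isobutyl, would give a clearly lower number.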